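Swapping Fluoro for Bromo in a Cytotoxicity Series

The source may report more compounds than this note shows. Statements on the series, on what has been measured and on what is new or still open speak of the compounds shown alone.

Of the compounds shown here, three have been measured in an ADME assay on HEK293 cells (Homo sapiens) for cytotoxicity, read by resazurin assay, with a stated time of 48 h; on this read-out higher numbers stand for lower toxicity in this test and lower numbers for higher toxicity in this test. Compound 1 `COc1c(Br)cccc1C(=O)Nc1ccc(Sc2nc3ccccc3s2)c(Cl)c1` gives 40000 nM. Compound 2 `O=C(Nc1ccc(Sc2nc3ccccc3s2)c(Cl)c1)c1cccc(Br)c1O` gives 68000 nM. Compound 3 `COc1ccc(S(=O)(=O)Nc2ccc3oc(-c4ccc(NS(=O)(=O)c5cc(F)ccc5OC)cc4)nc3c2)cc1` gives 24000 nM, the lowest of the three numbers; its gap to compound 1 lies within the scatter, while its gap to compound 2 lies beyond it. Among the measured compounds shown here, the only step between measured compounds that differ in one place is a 1.7-fold higher number from compound 1 to compound 2 (0.23 log units; within the scatter), where hydrogen replaces methyl on an oxygen attached to an aromatic ring.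

Compound 4 `COc1ccc(S(=O)(=O)Nc2ccc3oc(-c4ccc(NS(=O)(=O)c5cc(Br)ccc5OC)cc4)nc3c2)cc1` differs from compound 3 by bromo in place of fluoro on an aromatic carbon, so that the 5-fluoro-2-methoxyphenyl of compound 3 becomes a 5-bromo-2-methoxyphenyl. For the measured compounds named here, no measured step involves such a swap, so nothing in the data sets its size; the single step recorded concerns a different group and itself stays within the scatter. The step is therefore expected to be no change at the digits printed from compound 3 to compound 4 (within the scatter), nothing beyond the scatter. Compound 4 is estimated at 24000 nM, with a range from 12000 nM to 48000 nM.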

Compound 4, half-maximal cytotoxic concentration: 18000 nM
Compound 4: middle estimate off by 1.3-fold (0.12 log units), on the high side, within the range that was stated.
By their numbers in this assay, from the lowest: compounds 4, 3, 1 and 2 (each within the scatter of the next, the first and the last beyond it).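

In this assay, the step of a 1.3-fold lower number from compound 3 to compound 4 (0.12 log units; within the scatter) is the first one shown on an aromatic carbon rather than on an oxygen, and it stays within the scatter. Among the compounds shown here, at this place, para to a methoxy group, the read-out therefore does not separate fluoro from bromo, although the earlier compounds could say nothing about this position. No measurement of any other property bears on this result.

The compounds shown put only fluoro and bromo at this place, each a single atom with no hydrogen-bond donors or acceptors, so the effect of an amine, a carboxylic acid or a longer chain there remains open. Also open, from the compounds shown here alone, is whether the same exchange of bromo and fluoro would give a similarly small step on the core of compound 1.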